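The compounds below may be only part of what the source reports. "The series", "measured", "known", "first", "only" and "open" are said of these compounds alone.

Measured so far:
- compound 1, `CO[C@]1(C(=O)N2CC[C@](c3ccc(C(F)(C(F)(F)F)C(F)(F)F)cc3)(S(=O)(=O)c3ccc(F)cc3)C2)CC[C@H](C(=O)O)CC1`: 82%
- compound 2, `COC[C@]1(C(=O)N2CC[C@](c3ccc(C(F)(C(F)(F)F)C(F)(F)F)cc3)(S(=O)(=O)c3ccc(F)cc3)C2)CC[C@H](C(=O)O)CC1`: 100%
- compound 3, `O=C(O)[C@H]1CC[C@](F)(C(=O)N2CC[C@](c3ccc(C(F)(C(F)(F)F)C(F)(F)F)cc3)(S(=O)(=O)c3ccc(F)cc3)C2)CC1`: "not determined" (no result reported)

Within the data shown here, in an ADME assay on microsomes from liver (Homo sapiens) for metabolic stability, with a stated time of 10 min (a lower number here means that less of the compound is left, a higher number that more of the compound is left), compound 1 gives 82%, and compound 2 gives 100%, the highest of the two numbers known; the only difference between them is methoxymethyl in place of methoxy on a saturated ring carbon, and the step is a number 18 percentage points higher from compound 1 to compound 2 (beyond the scatter). Compound 3 carries no number in this assay.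

Compound 4, `O=C(O)C12CCC(C(=O)N3CC[C@](c4ccc(C(F)(C(F)(F)F)C(F)(F)F)cc4)(S(=O)(=O)c4ccc(F)cc4)C3)(CC1)OC2`, differs from compound 2 in this way: a group of 11 heavy atoms (8 carbon, 3 oxygen; one six-membered non-aromatic ring of carbon only, one six-membered non-aromatic ring with 1 hetero atom) in place of a group of 12 heavy atoms (9 carbon, 3 oxygen; one six-membered non-aromatic ring of carbon only), on a carbonyl carbon. Among the measured compounds shown here, no measured step matches this change. For the measured compounds named here, the one step known, from compound 1 to compound 2, alters the substituent on the same saturated ring carbon and is modest in size; it gives no direct guide for a change that joins the substituent into a second six-membered ring with one hetero atom. With compound 2 already at the top of the scale, the expected step is a number 10 percentage points lower from compound 2 to compound 4 (within the scatter), small or none beyond the scatter. Compound 4 is therefore estimated to give 90% in this assay, with a range from 72% to 100%.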

Compound 4, percent of the compound remaining: 90%
For compound 4 middle estimate and measured number coincide at the digits printed; the measured number falls inside the stated range.
By their numbers in this assay, from the lowest: compounds 1, 4 and 2 (each within the scatter of the next, the first and the last beyond it).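

In this assay, the group with a second six-membered ring holding one hetero atom, on the carbonyl carbon, gives a number 10 percentage points lower from compound 2 to compound 4 (within the scatter) and also a number 8 percentage points higher from compound 1 to compound 4 (within the scatter). Among these compounds, the earlier pair showed that this read-out can shift beyond the scatter with a change of substituent on the saturated ring carbon, whereas this two-ring group stays within the scatter of both open-chain ether compounds, so joining the ether oxygen into a ring produces no step that can be told apart here. Nothing given here accounts for these steps.

The compounds shown leave open whether an amine or a longer chain on that saturated ring carbon would stay within the same scatter. They also leave open whether a second ring holding nitrogen in place of oxygen would read like compound 4.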